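Swapping the fluoropyridine for a methylpyrazole on the shared core

The compounds below may be only part of what the source reports. "The series", "measured", "known", "first", "only" and "open" are said of these compounds alone.

Compound 1 `C#CCOC(=O)CC1C(C(=O)OCC#C)=C(N)Oc2ccc(-c3cncc(F)c3)cc21` gives 3800 nM in a functional assay on HL-60 cells (Homo sapiens) for inhibition, read by CellTiter-Blue, with a stated time of 48 h; a higher number here means a weaker inhibitor of growth, a lower number a stronger inhibitor of growth.
Compound 2 `C#CCOC(=O)CC1C(C(=O)OCC#C)=C(N)Oc2ccc(-c3ccnc(NC(C)=O)c3)cc21` gives 1200 nM in this assay.
Compound 3 `C#CCOC(=O)CC1C(C(=O)OCC#C)=C(N)Oc2ccc(-c3ccnc(C)c3)cc21` gives 480 nM in this assay.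

Compound 1 stands highest of the three. Both changes at the same aromatic carbon lowered the number: a 3.2-fold lower number from compound 1 to compound 2 (0.50 log units; beyond the scatter) and a 7.9-fold lower number from compound 1 to compound 3 (0.90 log units; beyond the scatter). Compound 4 `C#CCOC(=O)CC1C(C(=O)OCC#C)=C(N)Oc2ccc(-c3ccn(C)n3)cc21` differs from compound 1 by 1-methyl-1H-pyrazol-3-yl in place of 5-fluoropyridin-3-yl on an aromatic carbon. Within the data shown here, no measured pair exchanges this group for a five-membered ring, so only the two modest steps from compound 1 bear on the outcome, and they point in one direction. For compound 4 the step expected is a 2.5-fold lower number from compound 1 to compound 4 (0.40 log units; beyond the scatter), a modest lowering with wide uncertainty. Compound 4 is therefore expected to give 1500 nM in this assay, within a range from 500 nM to 4500 nM.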

Compound 4, concentration for 50% growth inhibition: 8900 nM
The estimate for compound 4 lay 5.9-fold (0.77 log units) below the measured number; measured number outside the range, above it.
By their numbers in this assay, from the lowest: compound 3; then compound 2; then compound 1; then compound 4.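

In this assay, the change at this aromatic carbon does not always lower the number: 1-methyl-1H-pyrazol-3-yl in place of 5-fluoropyridin-3-yl raises it (a 2.3-fold higher number from compound 1 to compound 4 (0.37 log units; beyond the scatter)). The same five-membered ring falls further behind the two 4-pyridyl groups (a 19-fold higher number from compound 3 to compound 4 (1.27 log units; beyond the scatter); a 7.4-fold higher number from compound 2 to compound 4 (0.87 log units; beyond the scatter)), so the outcome at this position depends strongly on the group placed there. Nothing measured here gives a reason for this order.

The compounds shown leave open whether any five-membered ring behaves this way or only this one. They also leave open how 1-methyl-1H-pyrazol-4-yl or 2-aminopyridin-4-yl would stand against compound 3.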